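This account rests on a few compounds, and the source may have more. Where it says the series, first, only, none or still open, it means among the compounds named here.

In a functional assay on MOLT-4 cells (Homo sapiens) for antiproliferative activity (a lower number here means a stronger inhibitor, a higher number a weaker inhibitor), three compounds on a shared core have been measured. Compound 1 `COc1cc(C(=O)c2sc(-c3ccc([N+](=O)[O-])cc3)cc2N)cc(OC)c1OC` carries a nitro group and gives 110 nM in this series. Compound 2 `COc1cc(C(=O)c2sc(-c3ccccc3)cc2N)cc(OC)c1OC` has hydrogen in that place and gives 5.3 nM as the lowest number. Compound 3 `COc1ccc(-c2cc(N)c(C(=O)c3cc(OC)c(OC)c(OC)c3)s2)cc1` has methoxy there and gives 18 nM as the middle of the three numbers, with compound 2 lower and compound 1 higher, both beyond the scatter.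

Compound 4 `CCOc1ccc(-c2cc(N)c(C(=O)c3cc(OC)c(OC)c(OC)c3)s2)cc1` differs from compound 3 in one small way. Its methoxy becomes ethoxy, which means methyl in place of hydrogen on a saturated chain carbon bound to an oxygen on an aromatic ring while the rest stays the same.

Going by the values given here, no measured step makes this exact change, so the closest guides are the swaps at the same place. Methoxy in place of hydrogen gave a 3.4-fold higher number from compound 2 to compound 3 (0.53 log units; beyond the scatter) and methoxy in place of nitro gave a 6.1-fold lower number from compound 1 to compound 3 (0.79 log units; beyond the scatter) while hydrogen in place of nitro gave a 21-fold lower number from compound 1 to compound 2 (1.32 log units; beyond the scatter) and so this place does respond to change. Those steps swap whole groups, whereas ethoxy only lengthens methoxy by one methyl. In this assay the expected outcome is a 1.2-fold higher number from compound 3 to compound 4 (0.09 log units; within the scatter) and thus no step beyond the scatter. Compound 4 is estimated at 22 nM with an expected range from 7 nM to 65 nM for now.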

Compound 4, half-maximal inhibitory concentration: 240 nM
Compound 4: the middle estimate sits 11-fold (1.04 log units) below what was measured; measured number outside the range, above it.
By their numbers in this assay, from the lowest: compound 2; then compound 3; then compound 1; then compound 4.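

In this assay, lengthening methoxy to ethoxy adds one methyl and gives a 13-fold higher number from compound 3 to compound 4 (1.12 log units; beyond the scatter), so this place responds strongly even to a single added carbon, and not only to swapping one whole group for another. The ethoxy group also compares poorly with the other groups at this place, with a 45-fold higher number from compound 2 to compound 4 (1.66 log units; beyond the scatter) for ethoxy in place of hydrogen and a 2.2-fold higher number from compound 1 to compound 4 (0.34 log units; beyond the scatter) for ethoxy in place of nitro, which means that ethoxy gives a weaker result here than even the nitro group, the weakest of the first three. Nothing available here accounts for why this one methyl makes so large a difference.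

The compounds shown leave open whether a longer chain such as propoxy would push the number higher still, or whether a branched group such as isopropoxy would behave like ethoxy. They also leave open whether an ethyl group placed directly on the aromatic carbon, with no oxygen, would give a number closer to that of methoxy or to that of ethoxy.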